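Thiophen-2-yl in Place of Iodo on a Nucleoside Core

The source may report more compounds than this note shows. Statements on the series, on what has been measured and on what is new or still open speak of the compounds shown alone.

Compound 3, `CNc1ncnc2c1c(I)cn2[C@@H]1O[C@H](CO)[C@@H](O)[C@H]1O`, stands in an ADME assay on BJ cells (Homo sapiens), read by MTT assay, with a stated time of 72 h (on this read-out higher numbers stand for weaker inhibition and lower numbers for stronger inhibition), only at a limit, giving > 100000 nM; this is the limit marked the limit of > 100000 nM in this assay, at which 1 of the 3 values shown sits, and not a number. Compound 2, `C#Cc1cn([C@@H]2O[C@H](CO)[C@@H](O)[C@H]2O)c2ncnc(NC)c12`, gives 86000 nM in this assay, and compound 1, `COc1ncnc2c1c(-c1cccs1)cn2[C@@H]1O[C@H](CO)[C@@H](O)[C@H]1O`, gives 62800 nM. For the measured compounds named here, the one measured step, an at least 1.1-fold higher number from compound 2 to compound 3 (0.06 log units; that floor lies within the scatter), concerns a different exchange. Compound 4, `CNc1ncnc2c1c(-c1cccs1)cn2[C@@H]1O[C@H](CO)[C@@H](O)[C@H]1O`, differs from compound 3 by thiophen-2-yl in place of iodo on an aromatic carbon. Going by the values given here, no measured step covers this change, so what is known of compound 4 rests on compound 1, which carries the same thiophen-2-yl group and gives 62800 nM. The estimated step is an at least 1.4-fold lower number from compound 3 to compound 4 (0.15 log units; that floor lies within the scatter), a move back to a measurable number. Compound 4 is therefore expected to give about 70000 nM in this assay, within 30000 nM to 150000 nM.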

Compound 4, half-maximal inhibitory concentration: > 100000 nM
Compound 4 ended at the assay's limit (the forecaster's own chance of this, stated with the estimate: 35%); at least 1.4-fold (0.15 log units) between middle value and limit.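

Thiophen-2-yl in place of iodo leaves compound 4 at a limit of the assay, as compound 3 is, so the step between them cannot be read, and in this assay this group does not by itself give a measurable number. Methylamino in place of methoxy gives an at least 1.5-fold higher number from compound 1 to compound 4 (0.20 log units; that floor lies within the scatter), and thiophen-2-yl in place of ethynyl gives an at least 1.1-fold higher number from compound 2 to compound 4 (0.06 log units; that floor lies within the scatter). Compound 3 and compound 4 thus rest at one limit: the limit of > 100000 nM in this assay, at which 2 of the 4 values shown sit.

Still open, from the compounds shown here alone, is whether an amine or a carboxylic acid on this aromatic carbon, with methylamino kept, would give a measurable number in this assay. Also open, going by these compounds, is whether any exchange here gives a step beyond the scatter.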